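Trimethoxyphenyl for fluorophenyl on a weak quinazoline-like series

The source may report more compounds than this note shows. Statements on the series, on what has been measured and on what is new or still open speak of the compounds shown alone.

Measured so far:
Compound 1, `O=C(CSc1nc(Nc2ccccc2)c2ccccc2n1)Nc1ccc(Cl)c(Cl)c1`: 37900 nM
Compound 2, `C=CC(=O)Nc1cccc(NC(=O)CSc2nc(Nc3ccccc3F)c3ccccc3n2)c1`: 26100 nM

Both compounds were tested in a functional assay on MGC-803 cells (Homo sapiens) for inhibition, read by MTT assay, with a stated time of 72 h; a higher number here means a weaker inhibitor, a lower number a stronger inhibitor. In this assay compound 1 gives 37900 nM and compound 2 gives 26100 nM. Compound 2 thus has the smaller of the two numbers, but its gap to compound 1 lies within the usual scatter, so the two cannot be told apart on these data; both are weak inhibitors.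

Compound 3, `C=CC(=O)Nc1cccc(NC(=O)CSc2nc(Nc3cc(OC)c(OC)c(OC)c3)c3ccccc3n2)c1`, has not yet been measured in this assay. It differs from compound 2 in one place: 3,4,5-trimethoxyphenyl in place of 2-fluorophenyl on a nitrogen on an aromatic ring. Among the measured compounds shown here, no measured pair that shares a change of this kind is available, so its effect cannot be read from the numbers here; the expectation below rests on the two values of compounds 1 and 2 and on the size of the change.

The step of a 1.7-fold lower number from compound 2 to compound 3 (0.24 log units; within the scatter) is expected to be a modest improvement, of a size that may or may not exceed the scatter. Compound 3 is therefore expected to give about 15000 nM in this assay, with a likely range from 4000 nM to 50000 nM.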

Compound 3, half-maximal inhibitory concentration: > 50000 nM
Compound 3: no number, only a limit; the forecaster's own chance of this, stated with the estimate: 5%; middle value at least 3.3-fold (0.52 log units) from the limit.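

Among the compounds shown here, this is the first view of what the group on this nitrogen does: replacing 2-fluorophenyl (7 heavy atoms, no hydrogen-bond acceptors) with 3,4,5-trimethoxyphenyl (12 heavy atoms, 3 hydrogen-bond acceptors) gives an at least 1.9-fold higher number from compound 2 to compound 3 (0.28 log units; that floor lies within the scatter) in this assay. Adding these atoms and acceptors at this position therefore brings no visible gain in potency, although the floor of the step does not show a real loss either. Compound 3 has no exact value, only a limit of the assay: the limit of > 50000 nM in this assay, at which 1 of the 3 values shown sits.

From the compounds shown here alone, the true size of this step remains open, as does which part of the change matters, the removal of the fluorine or the arrival of the three methoxy groups. Also open, going by these compounds, is how a single methoxy group, an amine or a carboxylic acid on this phenyl ring would compare, since one swap at this nitrogen cannot show whether the position tolerates any change or only some.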